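This account rests on a few compounds, and the source may have more. Where it says the series, first, only, none or still open, it means among the compounds named here.

Measured compounds in an ADME assay on microsomes from liver (Homo sapiens) for metabolic stability, read by LC-MS, with a stated time of 30 min, tested at 1 uM; a higher number here means that more of the compound is left, a lower number that less of the compound is left:

- compound 1 `CCNCc1cc(C)cc(Nc2nc3ccccc3n2Cc2ccc(C(F)(F)F)cc2)c1O`: 98%
- compound 2 `Cc1cc(CNC(C)(C)C)c(O)c(Nc2nc3ccccc3n2Cc2ccc(C(F)(F)F)cc2)c1`: 99%
- compound 3 `CCNCc1cc(Cl)cc(Nc2nc3cc(F)c(F)cc3[nH]2)c1O`: > 99%

Compound 1 and compound 2 both share the 4-(trifluoromethyl)benzyl group on the aromatic nitrogen of their core and both sit near the top of the scale in this assay. Within the data shown here, the only measured step, a number 1 percentage points higher from compound 1 to compound 2 (within the scatter), is a change on the amine nitrogen and does not touch the aromatic nitrogen. For compound 3 the value is a limit of the assay, not a number, as noted by the limit of > 99% in this assay, at which 1 of the 3 values shown sits; compound 3 thus stands at the upper end of the values shown, with no measurable headroom above it.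

Compound 4 `CCNCc1cc(Cl)cc(Nc2nc3cc(F)c(F)cc3n2Cc2ccc(C(F)(F)F)cc2)c1O` is to be measured in this assay. It differs from compound 3 in one place: 4-(trifluoromethyl)benzyl in place of hydrogen on an aromatic nitrogen. Among the measured compounds shown here, no measured step covers this exact change. What the shown values give is that compounds carrying the 4-(trifluoromethyl)benzyl group, compound 1 and compound 2, are almost fully retained, and compound 3 without it is at the limit. A step beyond the scatter is therefore not expected in either direction; the step of a number at least 2 percentage points lower from compound 3 to compound 4 (that floor lies within the scatter) is expected to stay within the scatter. Compound 4 is expected to give 97%, within a range of 89% to 100%.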

Compound 4, percent of the compound remaining: > 99%
Compound 4 was reported as a limit; the forecaster's own chance of this, stated with the estimate: 40%; at least 2 percentage points between middle value and limit.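

No step from compound 3 to compound 4 can be read in this assay, since both compounds stand at the same limit of the assay, which is not a number: the limit of > 99% in this assay, at which 2 of the 4 values shown sit.

The compounds shown leave open whether 4-(trifluoromethyl)benzyl in place of hydrogen on an aromatic nitrogen changes the percent of compound remaining at all.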